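Halogenated aryl swap on a pyridazinone amide series

A few compounds are considered here, and "the series" means these few. Any claim that something is new, unique, unknown or untested is made for them only; others in the source may bear on it.

Measured so far:
compound 1, `O=C(Nc1ccc(Oc2ccnc3[nH]ccc23)c(F)c1)c1nn(-c2ccc(Br)cc2F)ccc1=O`, 23500 nM
compound 2, `O=C(Nc1ccc(Oc2ccnc3[nH]ccc23)c(F)c1)c1nn(-c2ccc(Cl)c(F)c2)ccc1=O`, 11600 nM
compound 3, `Cn1ccc2c(Oc3ccc(NC(=O)c4nn(-c5ccc(Br)cc5F)ccc4=O)cc3)ccnc21`, 19800 nM

Of the compounds shown here, three have been measured in a functional assay on MCF7 cells (Homo sapiens) for cytotoxicity, read by MTT assay, with a stated time of 72 h; a higher number here means a weaker inhibitor, a lower number a stronger inhibitor. Compound 1 and compound 2 share one core; compound 3 carries a different core, and the difference between the two cores is not broken down here. Compound 1 and compound 3 lie within the scatter of each other, as do compound 2 and compound 3, so no order among them is claimed.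

Among the measured compounds shown here, the single counted change within the first pair is 4-chloro-3-fluorophenyl in place of 4-bromo-2-fluorophenyl on an aromatic nitrogen, and it gave a 2.0-fold lower number from compound 1 to compound 2 (0.31 log units; beyond the scatter) in this assay.

Compound 4, `Cn1ccc2c(Oc3ccc(NC(=O)c4nn(-c5ccc(Cl)c(F)c5)ccc4=O)cc3)ccnc21`, is not yet measured. It differs from compound 3 by 4-chloro-3-fluorophenyl in place of 4-bromo-2-fluorophenyl on an aromatic nitrogen, the same change as from compound 1 to compound 2, at a place described in identical words. Resting on compound 1 and compound 2, where this change gave a 2.0-fold lower number from compound 1 to compound 2 (0.31 log units; beyond the scatter), a step of similar size is expected, a 2.0-fold lower number from compound 3 to compound 4 (0.30 log units; within the scatter). Compound 4 is therefore estimated at 10000 nM in this assay, with a range from 5000 nM to 20000 nM.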

Compound 4, half-maximal inhibitory concentration: 16800 nM
Beside the measured number, compound 4's estimate is 1.7-fold (0.23 log units) below it, within the range that was stated.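

In this assay the swap to 4-chloro-3-fluorophenyl from 4-bromo-2-fluorophenyl gave a 1.2-fold lower number from compound 3 to compound 4 (0.07 log units; within the scatter) on this second core, so no gain from the change can be claimed there. The step on one core and the step on the other cannot be told apart, so a transfer of the change between cores is neither established nor refuted: the same change on two cores in this assay, a 2.0-fold lower number (0.31 log units; beyond the scatter) from compound 1 to compound 2 and a 1.2-fold lower number (0.07 log units; within the scatter) from compound 3 to compound 4, 1.7-fold (0.24 log units) apart, within the scatter of two such steps

With one pair on each core, and one of the two steps inside the scatter, nothing follows for any further core in the series.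

The swap replaces bromine with chlorine and also relocates the fluorine, so the compounds shown leave open which of these two differences carries the step seen on the first core. Also open, on these data alone, is how either core behaves when the aryl group on the aromatic nitrogen carries no halogen at all, for instance with an amine or a carboxylic acid in its place.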